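Aminocyclopentylamino in Place of Imidazolyl on the Shared Core

The compounds below may be only part of what the source reports. "The series", "measured", "known", "first", "only" and "open" are said of these compounds alone.

Compound 1 `COc1cc[nH]c1/C=C1\C(=O)Nc2ccc([N+](=O)[O-])c(N3CC[C@H](O)C3)c21`: 104 nM
Compound 2 `COc1cc[nH]c1/C=C1\C(=O)Nc2ccc([N+](=O)[O-])cc21`: 7460 nM
Compound 3 `COc1cc[nH]c1/C=C1\C(=O)Nc2ccc([N+](=O)[O-])c(-n3ccnc3)c21`: > 30000 nM

In a functional assay on MDA-MB-435 cells (Homo sapiens) for antiproliferative activity, read by MTT assay, with a stated time of 5 days (on this read-out lower numbers stand for stronger inhibition and higher numbers for weaker inhibition), compound 1 gives the lowest number shown. Compound 3 stands at the assay limit of > 30000 nM in this assay, at which 1 of the 3 values shown sits, and has no number of its own. The measured steps show an at least 280-fold higher number from compound 1 to compound 3 (2.46 log units; beyond the scatter) and an at least 4.0-fold higher number from compound 2 to compound 3 (0.60 log units; beyond the scatter), while a 72-fold higher number from compound 1 to compound 2 (1.86 log units; beyond the scatter). Compound 4 `COc1cc[nH]c1/C=C1\C(=O)Nc2ccc([N+](=O)[O-])c(N[C@H]3CC[C@H](N)C3)c21` differs from compound 3 by (3-aminocyclopentyl)amino in place of 1H-imidazol-1-yl on an aromatic carbon. Removing the 1H-imidazol-1-yl alone would, on the step from compound 3 back to compound 2, be expected to lower the number, and the (3-aminocyclopentyl)amino group that enters resembles the 3-hydroxypyrrolidin-1-yl of compound 1 more than the imidazolyl of compound 3. A large downward step is therefore expected, an at least 200-fold lower number from compound 3 to compound 4 (2.30 log units; beyond the scatter). Compound 4 is estimated at 150 nM, with a range from 30 nM to 1500 nM.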

Compound 4, half-maximal inhibitory concentration: 61 nM
Estimate against measurement, compound 4: 2.5-fold (0.39 log units) above; measured number inside the range.
By their numbers in this assay, from the lowest: compounds 4 and 1 (each within the scatter of the next); then compound 2. At a limit, above all of these: compound 3.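

At this place, ortho to a nitro group, a second group now gives a large gain over hydrogen in this assay, with a 120-fold lower number from compound 2 to compound 4 (2.09 log units; beyond the scatter), so the gain is not confined to 3-hydroxypyrrolidin-1-yl. The two groups cannot be told apart, with a 1.7-fold lower number from compound 1 to compound 4 (0.23 log units; within the scatter). Against 1H-imidazol-1-yl the change gives an at least 490-fold lower number from compound 3 to compound 4 (2.69 log units; beyond the scatter), a step that rests on a limit for compound 3: the limit of > 30000 nM in this assay, at which 1 of the 4 values shown sits.

The compounds shown leave open whether the amine on the cyclopentyl ring is needed, which a plain cyclopentylamino group would address. An open-chain aminoethylamino group would show whether the ring itself matters.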